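Dropping the amine methyl from compound 1

The compounds below may be only part of what the source reports. "The series", "measured", "known", "first", "only" and "open" are said of these compounds alone.

Measured so far:
compound 1 `CN1CCCN(c2cncc(-c3cc(CCO)no3)c2)CC1` — > 10000 nM
compound 2 `COCC[C@@H]1C[C@H]1c1cncc(N2CCCNCC2)c1` — 256 nM

In an assay on a protein complex for displacement of a labelled ligand from Neuronal acetylcholine receptor; alpha2/beta4 (Rattus norvegicus), read by scintillation counting (on this read-out higher numbers stand for weaker inhibition and lower numbers for stronger inhibition), compound 1 gives > 10000 nM, which is a limit of the assay rather than a number; it sits at the limit of > 10000 nM in this assay, at which 1 of the 2 values shown sits. Compound 3 `OCCc1cc(-c2cncc(N3CCCNCC3)c2)on1` has not yet been measured. It differs from compound 1 by hydrogen in place of methyl on an amine nitrogen in a ring, in words hydrogen in place of methyl on an amine nitrogen in a ring. For compound 3 a step to clearly stronger inhibition, well beyond the scatter, is expected, an at least 20-fold lower number from compound 1 to compound 3 (1.30 log units; beyond the scatter), since the unmethylated compound 2 gives 256 nM. Compound 3 is estimated at 500 nM, within a range from 80 nM to 4000 nM.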

Compound 3, inhibition constant: 331 nM
Compound 3: the middle estimate sits 1.5-fold (0.18 log units) above what was measured, and the stated range covers the measured number.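

Replacing methyl with hydrogen on an amine nitrogen in a ring gives, in this assay, an at least 30-fold lower number from compound 1 to compound 3 (1.48 log units; beyond the scatter), so this one nitrogen has a large bearing on the read-out for this core. Compound 1 gives only a limit of the assay, so the full size of the step stays unknown: the limit of > 10000 nM in this assay, at which 1 of the 3 values shown sits.

The compounds shown leave open how an ethyl or an acetyl group on this nitrogen would compare with methyl and hydrogen. They also leave open whether methyl there would have a similar effect on the core of compound 2.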